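Cytotoxicity notes on a methoxyquinoline amide series

The source may report more compounds than this note shows. Statements on the series, on what has been measured and on what is new or still open speak of the compounds shown alone.

Three compounds of the series have been run in an ADME assay on L6 cells (Rattus norvegicus) for cytotoxicity, read by resazurin assay, with a stated time of 70 h; on this read-out higher numbers stand for weaker inhibition and lower numbers for stronger inhibition. Compound 1 `COc1cc(NC(C)CCCNC(=O)/C(C)=C/c2ccccc2)c2ncccc2c1` carries a 1-methyl-2-phenylethenyl group on the carbonyl carbon; in this assay compound 1 gives only the limit > 250000 nM, not a number. Compound 2 `COc1ccc(/C=C/C(=O)NCCCC(C)Nc2cc(OC)cc3cccnc23)cc1` is the 2-(4-methoxyphenyl)ethenyl counterpart; in this assay compound 2 likewise gives the limit > 240000 nM. The step between them, a step that the two limits leave unreadable from compound 1 to compound 2, rests on the change 2-(4-methoxyphenyl)ethenyl in place of 1-methyl-2-phenylethenyl on a carbonyl carbon and cannot be sized, as both values sit at limits the limit of > 240000 nM in this assay, at which 1 of the 3 values shown sits (the limit of > 250000 nM in this assay, at which 1 of the 3 values shown sits). Within the data shown here, compound 3 `COc1cc(NC(C)CCCNC(=O)NNC(=O)/C(C)=C/c2ccccc2)c2ncccc2c1` is the one member with a number: in this assay compound 3 gives 36500 nM. How the core of compound 3 differs from the core of compound 1 is not broken down here.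

Compound 4 `COc1ccc(/C=C/C(=O)NNC(=O)NCCCC(C)Nc2cc(OC)cc3cccnc23)cc1` is not yet measured. It differs from compound 3 by 2-(4-methoxyphenyl)ethenyl in place of 1-methyl-2-phenylethenyl on a carbonyl carbon, the same change that takes compound 1 to compound 2, at the same place. Since that earlier step could not be read, the expected step for compound 4 is set near zero: a 1.1-fold higher number from compound 3 to compound 4 (0.04 log units; within the scatter) is the estimated step. For compound 4 in this assay the estimate is 40000 nM, expected between 12000 nM and 130000 nM.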

Compound 4, half-maximal inhibitory concentration: 3600 nM
Beside the measured number, compound 4's estimate is 11-fold (1.05 log units) above it; measured number outside the range, below it.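

In this assay, 2-(4-methoxyphenyl)ethenyl in place of 1-methyl-2-phenylethenyl on a carbonyl carbon gives a 10-fold lower number from compound 3 to compound 4 (1.01 log units; beyond the scatter), so on the core of compound 3 the change goes with a large step beyond the scatter. On the core of compound 1 the same change cannot be read, as compound 1 and compound 2 give only limits, so the data do not show whether the step carries from one core to the other; a single readable pair establishes no transfer and no failure of transfer. Nothing measured here bears on why the step arises.

Open, from the compounds shown here alone, is which part of the change goes with the step, as the methyl and the methoxy parts differ together between compound 3 and compound 4. Also open, going by these compounds, is how a plain 2-phenylethenyl group, or a 2-(4-aminophenyl)ethenyl group with its amine, would read on either core.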